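Swapping bromo for methyl on a cinnamamide-type scaffold

This account rests on a few compounds, and the source may have more. Where it says the series, first, only, none or still open, it means among the compounds named here.

Measured so far:
- compound 1, `COc1ccc(/C=C/C(=O)Nc2cc(-c3ccc(Br)cc3)[nH]n2)cc1`, 820 nM in a functional assay on A549 cells (Homo sapiens) for antiproliferative activity, read by MTT assay, with a stated time of 48 h; on this read-out lower numbers stand for stronger inhibition and higher numbers for weaker inhibition
- compound 2, `O=C(/C=C/c1ccc(Br)cc1)Nc1cc(-c2ccccc2)[nH]n1`, 1460 nM in this assay
- compound 3, `COc1ccc(/C=C/C(=O)Nc2cc(-c3ccc(C)cc3)[nH]n2)cc1`, 1190 nM in this assay

Of the compounds shown here, three have been tested in this assay, and their three values all lie close together; none of the gaps between them reaches beyond the usual scatter of repeated measurements.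

Compound 1 and compound 3 share a core and differ in one place only: methyl in place of bromo on an aromatic carbon. This change produced a 1.5-fold higher number from compound 1 to compound 3 (0.16 log units; within the scatter), a step that stays inside the scatter, so the two compounds cannot be told apart with confidence.

Compound 2 carries a different core from compound 1; how the two cores differ is not broken down here. On the core of compound 2, the same change is now to be made: compound 4, `Cc1ccc(/C=C/C(=O)Nc2cc(-c3ccccc3)[nH]n2)cc1`, differs from compound 2 by methyl in place of bromo on an aromatic carbon. The place is described in exactly the same words for both pairs, so this counts as the same change, seen a second time.

Among the measured compounds shown here, because the one earlier example of this change gave a 1.5-fold higher number from compound 1 to compound 3 (0.16 log units; within the scatter), a step of similar size is expected in this assay from compound 2 to compound 4, namely a 1.4-fold higher number from compound 2 to compound 4 (0.16 log units; within the scatter), with the caution that a single earlier example is a thin basis. Compound 4 is therefore expected to give about 2100 nM in this assay, most likely between 1000 nM and 4500 nM.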

Compound 4, half-maximal inhibitory concentration: 1770 nM
Compound 4: the middle estimate sits 1.2-fold (0.07 log units) above what was measured; measured number inside the range.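

Replacing bromo with methyl on the core of compound 2 gave a 1.2-fold higher number from compound 2 to compound 4 (0.08 log units; within the scatter), so compound 2 and compound 4 cannot be told apart in this assay. Seen a second time, on a different core, the change gives a step that cannot be separated from the first one: the same change on two cores in this assay, a 1.5-fold higher number (0.16 log units; within the scatter) from compound 1 to compound 3 and a 1.2-fold higher number (0.08 log units; within the scatter) from compound 2 to compound 4, 1.2-fold (0.08 log units) apart, within the scatter of two such steps. This shows that, for these two pairs, the swap from bromo to methyl carries from one core to the other in the plain sense that both steps stay inside the usual scatter, but it does not show that the change has any real effect on the number, and agreement between two such small steps says little about how a larger effect would transfer, or about any core beyond these two.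

The compounds shown leave open whether a different kind of group at this place, such as an amine, a carboxylic acid or a longer chain, would move the number by more than the scatter. They also leave open whether the swap from bromo to methyl would stay this small on a third core, which only further matched pairs in this assay could settle.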